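Replacing one 2-fluorophenyl group in compound 2

This account rests on a few compounds, and the source may have more. Where it says the series, first, only, none or still open, it means among the compounds named here.

Measured so far, all in a functional assay on QGY-7703 cells (Homo sapiens) for cytotoxicity, read by MTT assay, with a stated time of 24 h; a lower number here means a stronger inhibitor, a higher number a weaker inhibitor
compound 1 `O=C1/C(=C/c2ccccc2F)CN(S(=O)(=O)c2ccc(F)cc2)C/C1=C\c1ccccc1F` gives 8500 nM
compound 2 `CC(=O)Nc1ccc(S(=O)(=O)N2C/C(=C\c3ccccc3F)C(=O)/C(=C/c3ccccc3F)C2)cc1` gives 5500 nM
compound 3 `CC(=O)Nc1ccc(S(=O)(=O)N2C/C(=C\c3ccc(C#N)cc3)C(=O)/C(=C/c3ccc(C#N)cc3)C2)cc1` gives 3320 nM

Compound 2 at 5500 nM sits among these three numbers, within the scatter of each of the other two. The next compound to be tested is compound 4 `CC(=O)Nc1ccc(S(=O)(=O)N2C/C(=C\c3cccc([N+](=O)[O-])c3)C(=O)/C(=C/c3ccccc3F)C2)cc1`, which keeps the acetamido group of compound 2 and one of its 2-fluorophenyl groups. The change is 3-nitrophenyl in place of 2-fluorophenyl on a double-bonded chain carbon bound to a double-bonded ring carbon.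

Among the compounds with values here, the only measured step that changes one place, a 1.5-fold lower number from compound 1 to compound 2 (0.19 log units; within the scatter), is acetamido in place of fluoro on an aromatic carbon, so it does not test this site. The closest evidence is compound 3 at 3320 nM, which also carries the acetamido group, has different aryl groups at both double-bonded chain carbons and still stays within the scatter of compound 2. Within the data shown here, no measured compound carries a nitro group, so this evidence is thin. No shift beyond the scatter is therefore expected, and the estimate is a 1.3-fold lower number from compound 2 to compound 4 (0.12 log units; within the scatter) in size. For compound 4 the estimated value is 4200 nM, with an expected range from 1900 nM to 9000 nM.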

Compound 4, half-maximal inhibitory concentration: 7850 nM
Estimate against measurement, compound 4: 1.9-fold (0.27 log units) below; the range from low to high includes it.
By their numbers in this assay, from the lowest: compounds 3, 2, 4 and 1 (each within the scatter of the next, the first and the last beyond it).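

In this assay, within the data shown here, putting 3-nitrophenyl in place of 2-fluorophenyl on a double-bonded chain carbon bound to a double-bonded ring carbon gives a 1.4-fold higher number from compound 2 to compound 4 (0.15 log units; within the scatter) and is the one single-place step read at this position. The position therefore accepts this exchange of one aryl group, with its added nitro group and two hydrogen-bond acceptors, without a shift beyond the scatter, and the series now holds a compound with different aryl groups on its two double-bonded chain carbons, whereas compounds 1, 2 and 3 each carry a matching pair. No measured property of either aryl group bears on this result, and the step offers no explanation for it.

Still open, going by these compounds, is whether any group at this position moves the number beyond the scatter, for example a phenyl ring carrying an amine or a carboxylic acid in place of the nitro group. On these data alone, it is also open whether 3-nitrophenyl gives a comparable step at the second double-bonded chain carbon, or when the acetamido group gives way to fluoro on the aromatic carbon.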